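Swapping butyl for sec-butyl on compound 3

A few compounds are considered here, and "the series" means these few. Any claim that something is new, unique, unknown or untested is made for them only; others in the source may bear on it.

In a functional assay on the whole organism (strain Sprague-Dawley) for inhibition, with Rattus norvegicus as the target, with a stated time of 10 min (on this read-out higher numbers stand for an effect only at larger amounts of compound and lower numbers for an effect already at smaller amounts), compound 3 (`CCCCOc1ccccc1-c1ncc(C(=O)O)c(=O)[nH]1`) gives 0.5 mg/kg, level with compound 1 (`CCOc1ccccc1-c1ncc(C(=O)O)c(=O)[nH]1`) at 0.5 mg/kg. Compound 2 (`CCCOc1ccccc1-c1ncc(C(=O)O)c(=O)[nH]1`) gives 0.9 mg/kg, within the scatter of both. Compound 4 (`CCC(C)Oc1ccccc1-c1ncc(C(=O)O)c(=O)[nH]1`) carries sec-butyl in place of butyl on an oxygen on an aromatic ring. The measured steps that bear on this change alter the same chain: a 1.8-fold higher number from compound 1 to compound 2 (0.26 log units; within the scatter), a 1.8-fold lower number from compound 2 to compound 3 (0.26 log units; within the scatter) and no change at the digits printed from compound 1 to compound 3 (within the scatter). All three stay within the scatter, although none tests a branched chain. No step beyond the scatter is therefore expected in this assay, and the expected step is a 1.4-fold higher number from compound 3 to compound 4 (0.15 log units; within the scatter). Compound 4 is estimated at 0.7 mg/kg, with an expected range from 0.3 mg/kg to 1.6 mg/kg.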

Compound 4, dose for 50% inhibition: 0.5 mg/kg
Estimate against measurement, compound 4: 1.4-fold (0.15 log units) above, and the stated range covers the measured number.
By their numbers in this assay, from the lowest: compounds 1, 3, 4 and 2 (each within the scatter of the next).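

In this assay, within the data shown here, sec-butyl is the first branched chain on this oxygen, and replacing butyl with it leaves the number unmoved (no change at the digits printed from compound 3 to compound 4 (within the scatter)). Compound 4 also stays within the scatter of the two shorter straight chains (a 1.8-fold lower number from compound 2 to compound 4 (0.26 log units; within the scatter); no change at the digits printed from compound 1 to compound 4 (within the scatter)), so branching at the saturated chain carbon bound to the oxygen on the aromatic ring is accommodated here as well as the changes in chain length were. Nothing measured here offers an explanation for this result.

From the compounds shown here alone, whether a longer chain such as octyl, a cyclopentyl ring or a chain ending in an amine would also stay within the scatter remains open.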